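Chloro for Methoxy: From Compound 1 to Compound 4

The source may report more compounds than this note shows. Statements on the series, on what has been measured and on what is new or still open speak of the compounds shown alone.

Of the compounds shown here, three have so far been tested in a functional assay, with a stated time of 20 min; a higher number here means a weaker inhibitor, a lower number a stronger inhibitor. Compound 1 `CCOC(=O)c1cnn(-c2nc(-c3ccc(OC)cc3)c(C#N)c(=O)n2C)c1N` gives 59 ug/mL in this assay. Compound 2 `CSc1nc(-c2ccco2)c(C#N)c(=O)n1C` gives 68 ug/mL, and compound 3 `COc1cccc(-c2nc(SC)n(C)c(=O)c2C#N)c1OC` gives 54 ug/mL. Among these three numbers, compound 1 stands second highest; its nearest neighbour is compound 3 and its furthest is compound 2, but both gaps lie within the usual scatter of repeated measurements, so the three cannot be ranked against one another.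

Compound 4 `CCOC(=O)c1cnn(-c2nc(-c3ccc(Cl)cc3)c(C#N)c(=O)n2C)c1N` has not yet been measured. It differs from compound 1 in a single place (chloro in place of methoxy on an aromatic carbon). The same difference, cut one bond further out, reads 4-methoxyphenyl to 4-chlorophenyl.

Among the measured compounds shown here, no pair of measured compounds shows this change, so its effect in this assay is unknown from these data. The three measured numbers sit close together, which gives no hint of a move beyond the scatter. Compound 4 is therefore expected to give about 55 ug/mL, in a range from 25 ug/mL to 120 ug/mL. That estimate means a step of a 1.1-fold lower number from compound 1 to compound 4 (0.03 log units; within the scatter) that is expected to stay within the scatter, in no clear direction.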

Compound 4, half-maximal inhibitory concentration: 64 ug/mL
Beside the measured number, compound 4's estimate is 1.2-fold (0.07 log units) below it, and the stated range covers the measured number.
By their numbers in this assay, from the lowest: compounds 3, 1, 4 and 2 (each within the scatter of the next).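

In this assay, chloro in place of methoxy on this aromatic carbon gives a 1.1-fold higher number from compound 1 to compound 4 (0.04 log units; within the scatter), so compound 1 and compound 4 cannot be told apart. Among the compounds shown here, this is the first direct comparison at this position, and it shows that replacing methoxy, which counts one hydrogen-bond acceptor, with chloro, which counts none, leaves the result within the scatter for this pair. Nothing shown here offers an explanation for this result.

As far as these compounds go, it remains open whether another group at this position, such as an amine or a carboxylic acid, would produce a step beyond the scatter. It is also open whether chloro in place of methoxy would give a similar result elsewhere on the core, as this single pair is the only example shown.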